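This account rests on a few compounds, and the source may have more. Where it says the series, first, only, none or still open, it means among the compounds named here.

In a functional assay on A549 cells (Homo sapiens) for inhibition, read by sulforhodamine B assay, with a stated time of 48 h (a lower number here means a stronger inhibitor of growth, a higher number a weaker inhibitor of growth), compound 1 (`Cc1ccn2c(CN3CCCCC3)c(-c3ccccc3)nc2n1`) gives 4040 nM. This places it at the high end of the three measured numbers, level within the scatter with compound 2 (`Cc1ccn2c(CN3CCCC3)c(-c3ccc(O)cc3)nc2n1`), which gives 2480 nM. Compound 3 (`c1ccc(-c2nc3ncccn3c2CN2CCCCC2)cc1`) lies well apart at 260 nM. The next compound, compound 4 (`Cc1ccn2c(CN3CCCCC3)c(C(C)(C)C)nc2n1`), has tert-butyl in place of phenyl on an aromatic carbon. Within the data shown here, only one measured step is a clean single change, and it lies elsewhere on the core: hydrogen in place of methyl on an aromatic carbon gives a 16-fold lower number from compound 1 to compound 3 (1.19 log units; beyond the scatter), a large step. It shows that a small edit can matter in this series, but it says nothing directly about replacing phenyl. Compound 2 differs from compound 1 in more than one place, so it gives no clean comparison. With no direct evidence, a moderate loss of growth inhibition is expected on swapping an aromatic ring for a group without a ring, though this is uncertain. The expected change is a 2.0-fold higher number from compound 1 to compound 4 (0.30 log units; within the scatter). For compound 4 the estimated value is 8000 nM, with an expected range from 2500 nM to 25000 nM.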

Compound 4, concentration for 50% growth inhibition: 7390 nM
Compound 4: middle estimate off by 1.1-fold (0.03 log units), on the high side; low and high end bracket the measured number.
By their numbers in this assay, from the lowest: compound 3; then compounds 2, 1 and 4 (each within the scatter of the next, the first and the last beyond it).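

In this assay, putting tert-butyl in place of phenyl gives a 1.8-fold higher number from compound 1 to compound 4 (0.26 log units; within the scatter). Among these compounds, this is the first direct reading at this position, and it shows that the swap makes no difference that can be told from the scatter, even though tert-butyl has no ring and fewer heavy atoms. No measurement shown here accounts for this result.

Still open, on these data alone, is whether an amine, a carboxylic acid or a longer chain on this carbon would also stay level with compound 1, or would shift the number as strongly as the edit elsewhere on the core, which gives a 16-fold lower number from compound 1 to compound 3 (1.19 log units; beyond the scatter). Also open, as far as these compounds go, is whether tert-butyl in place of phenyl would leave the number unchanged on the core of compound 3, which lacks the methyl group and gives 260 nM.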